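The source may report more compounds than this note shows. Statements on the series, on what has been measured and on what is new or still open speak of the compounds shown alone.

Two compounds of one shared core have been run through an assay on membranes from brain for displacement of a labelled ligand from adenosine receptor A1 (Cavia porcellus) (on this read-out higher numbers stand for weaker inhibition and lower numbers for stronger inhibition), so far. Compound 1, `CCCn1c(=O)n(C)c(=O)c2[nH]cnc21`, gives 1900 nM in this assay. Compound 2, `CCCn1cnc2c1c(=O)[nH]c(=O)n2CCC`, gives 18200 nM in this assay. Of the two numbers, compound 2 stands highest, and the gap to compound 1 is beyond the usual scatter, so compound 2 is the weaker of the pair. Going by the values given here, no pair of measured compounds differs in only one place, so no single step has been measured yet.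

Compound 3, `CCCn1cnc2c1c(=O)n(C)c(=O)n2CCC`, is the next compound to be measured in this assay. Relative to compound 2, the change is methyl in place of hydrogen on an aromatic nitrogen. Methyl groups on the aromatic nitrogens of this core are a feature compound 1 also carries, and compound 1 sits well below compound 2 in this assay, so the step from compound 2 to compound 3 is expected to go downward, toward stronger inhibition, by a 4.6-fold lower number from compound 2 to compound 3 (0.66 log units; beyond the scatter). The estimate for compound 3 is 4000 nM, within a range from 1200 nM to 13000 nM.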

Compound 3, inhibition constant: 9400 nM
For compound 3 the middle estimate is 2.4-fold (0.37 log units) below the measured one; low and high end bracket the measured number.
By their numbers in this assay, from the lowest: compound 1; then compounds 3 and 2 (each within the scatter of the next).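

In this assay, methyl in place of hydrogen on the aromatic nitrogen gives a 1.9-fold lower number from compound 2 to compound 3 (0.29 log units; within the scatter) and so does not set these two compounds apart, which means this methyl on its own has no effect that can be read here. The propyl change on an aromatic nitrogen gives a clearer result, a 4.9-fold higher number from compound 1 to compound 3 (0.69 log units; beyond the scatter), so of the two steps only this modest one stands out from the scatter. The data offer no measured explanation for either step.

On these data alone, what an ethyl group, a benzyl group or a chain ending in an amine would do at this nitrogen remains open. Also open, as far as these compounds go, is whether the methyl step would stay this small if either propyl group of compound 3 were replaced by a shorter or longer chain.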